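Swapping 3-fluorophenyl for oxan-4-yl on a carbonyl carbon

A few compounds are considered here, and "the series" means these few. Any claim that something is new, unique, unknown or untested is made for them only; others in the source may bear on it.

- compound 1 `C[C@H](NC(=O)C1CCOCC1)c1ccc(NC(=O)N2CC(c3ccc(N)nc3)C2)cc1` gives 110 nM
- compound 2 `C[C@H](NC(=O)c1cccc(F)c1)c1ccc(NC(=O)N2CC(c3cncc(N)c3)C2)cc1` gives 630 nM

In a functional assay on COR-L23 cells (Homo sapiens) for antiproliferative activity, read by CellTiter-Glo, with a stated time of 72 h (a higher number here means a weaker inhibitor, a lower number a stronger inhibitor), compound 2 has the higher number of the two, and its gap to compound 1 lies beyond the scatter. For the measured compounds named here, compound 3 `C[C@H](NC(=O)C1CCOCC1)c1ccc(NC(=O)N2CC(c3cncc(N)c3)C2)cc1` keeps the rest of compound 2 but has oxan-4-yl in place of 3-fluorophenyl on a carbonyl carbon as its one change. Compound 1 also carries oxan-4-yl and gives 110 nM in this assay but has a different aminopyridine end, so it is only a loose guide. A modest move toward a lower number is expected a 1.8-fold lower number from compound 2 to compound 3 (0.26 log units; within the scatter) and may stay within the scatter. The estimated value for compound 3 is 350 nM (expected range 100 nM to 1200 nM).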

Compound 3, half-maximal inhibitory concentration: 970 nM
Estimate against measurement, compound 3: 2.8-fold (0.44 log units) below, within the range that was stated.
By their numbers in this assay, from the lowest: compound 1; then compounds 2 and 3 (each within the scatter of the next).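

In this assay, with the 5-aminopyridin-3-yl end in place, 3-fluorophenyl and oxan-4-yl on this carbonyl carbon cannot be told apart (a 1.5-fold higher number from compound 2 to compound 3 (0.19 log units; within the scatter)). With oxan-4-yl held fixed, the aminopyridine end does count: 5-aminopyridin-3-yl in place of 6-aminopyridin-3-yl on a saturated ring carbon gives a clear step (an 8.8-fold higher number from compound 1 to compound 3 (0.95 log units; beyond the scatter)). Nothing available explains either step.

As far as these compounds go, whether 3-fluorophenyl and oxan-4-yl also read alike with the 6-aminopyridin-3-yl end remains open. So does how a piperidin-4-yl or a plain methyl group would read on this carbonyl carbon.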